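The compounds below may be only part of what the source reports. "The series", "measured", "known", "first", "only" and "open" are said of these compounds alone.

Measured so far in a functional assay on HCT-116 cells (Homo sapiens) for cytotoxicity, read by MTT assay, with a stated time of 48 h; a lower number here means a stronger inhibitor, a higher number a weaker inhibitor:
compound 1 `CNC(=O)c1ccc(Sc2cccc(NC(=S)Nc3ccc(Cl)c(C(F)(F)F)c3)c2)nc1` — 5180 nM
compound 2 `CNC(=O)c1ccc(Sc2cccc(NC(=S)Nc3ccc(F)c(C(F)(F)F)c3)c2)nc1` — 18200 nM
compound 3 `CNC(=O)c1ccc(Sc2ccc(NC(=S)Nc3ccc(F)c(C(F)(F)F)c3)cc2)nc1` — 6370 nM

Compounds 1 and 2 share one core and differ by chloro in place of fluoro on an aromatic carbon, a change that gave a 3.5-fold lower number from compound 2 to compound 1 (0.55 log units; beyond the scatter). Compound 3 carries the other core; how the two cores differ is not broken down here, and in this assay compound 3 and compound 1 lie within the usual scatter of each other, while compound 3 sits beyond it against compound 2. Compound 4 `CNC(=O)c1ccc(Sc2ccc(NC(=S)Nc3ccc(Cl)c(C(F)(F)F)c3)cc2)nc1` is not yet measured; it differs from compound 3 by chloro in place of fluoro on an aromatic carbon, the same change seen from compound 2 to compound 1, at a place described in identical words. On the strength of the earlier step, the account expects a comparable but somewhat smaller move, a 2.5-fold lower number from compound 3 to compound 4 (0.41 log units; beyond the scatter), since the step from compound 2 to compound 1 stands alone and one pair cannot fix the size. Compound 4 is therefore estimated at 2500 nM, most likely between 1000 nM and 6500 nM.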

Compound 4, half-maximal inhibitory concentration: 4900 nM
Estimate against measurement, compound 4: 2.0-fold (0.29 log units) below; measured number inside the range.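

In this assay, chloro in place of fluoro on an aromatic carbon gave a 1.3-fold lower number from compound 3 to compound 4 (0.11 log units; within the scatter). Set beside the earlier step, the same change did not carry over at the same size from one core to the other: the same change on two cores in this assay, a 3.5-fold lower number (0.55 log units; beyond the scatter) from compound 2 to compound 1 and a 1.3-fold lower number (0.11 log units; within the scatter) from compound 3 to compound 4, 2.7-fold (0.43 log units) apart, beyond the scatter of two such steps. Going by these compounds alone, this shows that, in this series, the earlier step cannot be applied to the other core as a fixed amount, but with only one pair on each core it does not show why the two steps differ or what the change would do on a further core.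

The compounds shown leave open what a bromo or a methyl would do in place of the chloro on either core. They also leave open how a urea in place of the thiourea would compare.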